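Hydroxy and nitro exchange in compound 2

This account rests on a few compounds, and the source may have more. Where it says the series, first, only, none or still open, it means among the compounds named here.

In a functional assay on DU-145 cells (Homo sapiens) for inhibition, read by trypan blue exclusion, with a stated time of 96 h (a lower number here means a stronger inhibitor of growth, a higher number a weaker inhibitor of growth), compound 1 `Cc1ccc(CS/C(=C/c2ccc(F)c(C)c2)C(=O)c2ccc(Cl)cc2)cc1` gives 25000 nM and compound 2 `COc1cc(C(=O)/C(=C\c2ccc(O)c([N+](=O)[O-])c2)SCc2ccc(Br)cc2)cc(OC)c1OC` gives 1000 nM, the lower of the two numbers, with a gap beyond the scatter. For compound 3 `O=C(/C(=C\c1cc([N+](=O)[O-])ccc1F)S(=O)(=O)Cc1ccc(F)cc1)c1ccc(Br)cc1`, the reading of > 100000 nM is a limit of the assay, not a number.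

Compound 4 `COc1cc(C(=O)/C(=C\c2ccc([N+](=O)[O-])c(O)c2)SCc2ccc(Br)cc2)cc(OC)c1OC` has the same atoms as compound 2, joined differently: 3-hydroxy-4-nitrophenyl in place of 4-hydroxy-3-nitrophenyl on a double-bonded chain carbon bound to a double-bonded chain carbon. Going by the values given here, no measured pair isolates this exchange, so only a modest move towards a higher number in this assay is expected, anchored on compound 2 at 1000 nM. The expected step is a 2.0-fold higher number from compound 2 to compound 4 (0.30 log units; within the scatter). For compound 4, the estimated value is 2000 nM, with an expected range of 400 nM to 12000 nM.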

Compound 4, concentration for 50% growth inhibition: 1000 nM
Compound 4: middle estimate off by 2.0-fold (0.30 log units), on the high side; low and high end bracket the measured number.
By their numbers in this assay, from the lowest: compounds 2 and 4 (each within the scatter of the next); then compound 1. At a limit, above all of these: compound 3.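

In this assay, 3-hydroxy-4-nitrophenyl in place of 4-hydroxy-3-nitrophenyl gives no change at the digits printed from compound 2 to compound 4 (within the scatter). Going by these compounds alone, this is the only one-place comparison so far, and it shows that this position accepts the exchange of the two groups without a readable shift in growth inhibition. No measurement shown bears on why the exchange leaves the reading unmoved. On these data alone, whether the hydroxy and nitro groups are needed at all remains open. So does the effect of an amine or a carboxylic acid in place of the nitro group.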